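Opening the Ring: Compound 3 to Compound 4

The compounds below may be only part of what the source reports. "The series", "measured", "known", "first", "only" and "open" are said of these compounds alone.

Compound 1 `CCC(=O)Nc1cccc(Oc2nc(Nc3ccc(N4CCN(C)CC4)cc3)ncc2Cl)c1` gives 92.9% in an assay on isolated protein for inhibition of NUAK family SNF1-like kinase 1 (Homo sapiens), read by ADP-Glo, with a stated time of 60 min, tested at 10 uM, in the presence of a further agent that is not named here; on this read-out lower numbers stand for less inhibition and higher numbers for more inhibition at the one concentration tested (going by the name of the read-out).
Compound 2 `CCC(=O)Nc1cccc(Oc2nc(Nc3ccc(N4CCC(OC)CC4)cc3)ncc2Cl)c1` gives 86.5% in this assay.
Compound 3 `CCC(=O)Nc1cccc(Oc2nc(Nc3ccc(N4CCCCC4)cc3)ncc2Cl)c1` gives 86% in this assay.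

Compound 3 shows the smallest of the three numbers, but its gaps to the others are within the scatter: a number 6.9 percentage points lower from compound 1 to compound 3 (within the scatter) and a number 0.5 percentage points lower from compound 2 to compound 3 (within the scatter). Compound 4 `CCC(=O)Nc1cccc(Oc2nc(Nc3ccc(N(CC)CC)cc3)ncc2Cl)c1` differs from compound 3 in one place: diethylamino in place of piperidin-1-yl on an aromatic carbon. Within the data shown here, no measured step opens a ring in this way; the nearest comparisons are the exchanges of the group on that aromatic carbon, a number 6.4 percentage points lower from compound 1 to compound 2 (within the scatter) and a number 0.5 percentage points lower from compound 2 to compound 3 (within the scatter), both within the scatter. The expectation is therefore a small step, a number 2 percentage points lower from compound 3 to compound 4 (within the scatter), not beyond the scatter. Compound 4 is estimated at 84% in this assay, between 70% and 94%.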

Compound 4, a percentage reported as inhibition, at one concentration (the size of the read-out at that concentration, not a potency): 54.4%
The estimate for compound 4 lay 29.6 percentage points above the measured number; the measured number lies below the stated range.
By their numbers in this assay, from the lowest: compound 4; then compounds 3, 2 and 1 (each within the scatter of the next).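

In this assay, among these compounds, the diethylamino group gives the first steps beyond the scatter at this aromatic carbon: a number 31.6 percentage points lower from compound 3 to compound 4 (beyond the scatter), a number 32.1 percentage points lower from compound 2 to compound 4 (beyond the scatter) and a number 38.5 percentage points lower from compound 1 to compound 4 (beyond the scatter). Among the compounds shown here, the three groups with a six-membered ring lie within the scatter of each other, whereas the one group without a ring stands apart from all of them. Nothing measured here explains the drop. The compounds shown leave open whether the ring itself or the size of the group counts. A pyrrolidin-1-yl ring and a dimethylamino group at this place would help separate the two.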